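The compounds below may be only part of what the source reports. "The series", "measured", "known", "first", "only" and "open" are said of these compounds alone.

Compound 3 `CCCCN(C)c1cc(C(C)(C)C)ccc1CNC(=O)C(C)c1ccc(NS(C)(=O)=O)c(F)c1` gives the lowest of the three measured numbers in an assay on cells for antagonist activity at transient receptor potential cation channel subfamily V member 1 (Homo sapiens), read by FLIPR and calcium flux, with a stated time of 6 min (on this read-out lower numbers stand for stronger inhibition and higher numbers for weaker inhibition), at 1 nM. Compound 1 `CC(C)Oc1nc(C(C)(C)C)ccc1CNC(=O)C(C)c1ccc(NS(C)(=O)=O)c(F)c1` gives 2.3 nM in this assay, and compound 2 `CC(C(=O)NCc1ccc(C(C)(C)C)nc1C1CCCCC1)c1ccc(NS(C)(=O)=O)c(F)c1` gives 3.1 nM. Within the data shown here, the only step between measured compounds that differ in one place, a 1.3-fold higher number from compound 1 to compound 2 (0.13 log units; within the scatter), swaps one substituent for another on the aromatic carbon carrying the variable group and leaves the read-out essentially where it was.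

Compound 4 `CC(C)CCOc1cc(C(C)(C)C)ccc1CNC(=O)C(C)c1ccc(NS(C)(=O)=O)c(F)c1` differs from compound 3 by isopentyloxy in place of butyl(methyl)amino on an aromatic carbon. Among the measured compounds shown here, no measured step covers exactly this exchange. The step from compound 1 to compound 2 is the nearest guide, since it also exchanges the substituent on that carbon, and it stayed within the scatter. Beyond that, compound 1, which carries an alkoxy group at this carbon, and compound 3 show numbers that lie apart by more than the scatter, with compound 1 the higher of the two; compound 4 returns to an alkoxy group there, so a modest rise toward the number of compound 1 is plausible, though the longer chain of isopentyloxy has no direct precedent among these compounds.

Compound 4 is therefore expected to give a step of a 2.0-fold higher number from compound 3 to compound 4 (0.30 log units; within the scatter), a small rise that may fall within the scatter. The estimate for compound 4 in this assay is 2 nM, with a range from 0.8 nM to 5 nM.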

Compound 4, inhibition constant: 0.6 nM
Estimate against measurement, compound 4: 3.3-fold (0.52 log units) above; measured number outside the range, below it.
By their numbers in this assay, from the lowest: compounds 4 and 3 (each within the scatter of the next); then compounds 1 and 2 (each within the scatter of the next).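

On this carbon, ortho to a large group and meta to a tert-butyl group, isopentyloxy can stand in for butyl(methyl)amino with a 1.7-fold lower number from compound 3 to compound 4 (0.22 log units; within the scatter) in this assay, so the nitrogen-linked group is not needed to keep the number this low. Both groups carry 6 heavy atoms and no ring, and this exchange, made on the six-membered aromatic ring of carbon only, joins a 1.3-fold higher number from compound 1 to compound 2 (0.13 log units; within the scatter) on the core of compound 1 as a second one-place change at this carbon that stays within the scatter, with no such step among these compounds going against it. No measurement shown here gives a reason for this tolerance.

Because the linking atom and the chain shape change together from compound 3 to compound 4, the compounds shown leave open what each contributes alone, which a straight butoxy group or an isopentyl(methyl)amino group would separate. They also leave open whether a much shorter chain such as methoxy, or a carboxylic acid, on this carbon would keep the number in the same range.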